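A Chloro Group Leaves the Dichlorophenyl Compound

A few compounds are considered here, and "the series" means these few. Any claim that something is new, unique, unknown or untested is made for them only; others in the source may bear on it.

Compound 1 `O=c1oc2ccccc2c2nc3c(ccc4cc[nH]c43)c(-c3cccnc3Cl)c12`: 70700 nM
Compound 2 `O=c1oc2ccccc2c2nc3c(ccc4cc[nH]c43)c(-c3ccc([N+](=O)[O-])cc3)c12`: 70700 nM
Compound 3 `O=c1oc2ccccc2c2nc3c(ccc4cc[nH]c43)c(-c3ccc(Cl)cc3Cl)c12`: 70700 nM

These three compounds share one core and differ only in the aromatic group it carries. In a functional assay on B16-F10 cells (Mus musculus) for cytotoxicity (on this read-out lower numbers stand for stronger inhibition and higher numbers for weaker inhibition), compound 3 gives 70700 nM, which puts it level with the other two compounds, with no separation among the three.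

The next compound to be tested is compound 4 `O=c1oc2ccccc2c2nc3c(ccc4cc[nH]c43)c(-c3ccc(Cl)cc3)c12`. It is reached from compound 3 by the change hydrogen in place of chloro on an aromatic carbon, so that 2,4-dichlorophenyl becomes 4-chlorophenyl.

Going by the values given here, no measured step makes this exact change, so the evidence is indirect. Three steps exchange the whole aromatic group: no change at the digits printed from compound 1 to compound 2 (within the scatter), no change at the digits printed from compound 1 to compound 3 (within the scatter) and no change at the digits printed from compound 2 to compound 3 (within the scatter). The last two bear most closely, since they lead to the 2,4-dichlorophenyl group of compound 3. None of the three moved the read-out, although each exchange was larger than the loss of a single chloro group.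

A step beyond the scatter is therefore not expected in this assay, and no direction is favoured. The expected outcome is no change at the digits printed from compound 3 to compound 4 (within the scatter). The estimate for compound 4 is 70700 nM, with an expected range from 32000 nM to 125000 nM.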

Compound 4, half-maximal inhibitory concentration: 70700 nM
Estimate against measurement, compound 4: no gap at the digits printed; the range from low to high includes it.
By their numbers in this assay, from the lowest: compounds 1, 2, 3 and 4 (each within the scatter of the next).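

In this assay the chloro group ortho to a large group and meta to a chloro group could be replaced by hydrogen with no change at the digits printed from compound 3 to compound 4 (within the scatter) as the outcome, so a change of a single heavy atom at this position joins the earlier exchanges of the whole aromatic group. The 4-chlorophenyl group also falls in with the other aromatic groups, with no change at the digits printed from compound 2 to compound 4 (within the scatter) for chloro in place of nitro and no change at the digits printed from compound 1 to compound 4 (within the scatter) for 4-chlorophenyl in place of 2-chloropyridin-3-yl, so all four compounds now share one printed value. Nothing available here accounts for this flat result.

As far as these compounds go, it remains open whether any group at this position can move the read-out at all, for example a phenyl ring carrying an amine or a carboxylic acid, or a longer chain in place of the ring. The compounds shown also leave open whether a change elsewhere on the shared core, such as a substituent on the indole-type nitrogen hydrogen's place, would shift the number.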